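Ester Tail Branching in a Retinoid-Type Amide Series

The compounds below may be only part of what the source reports. "The series", "measured", "known", "first", "only" and "open" are said of these compounds alone.

Measured compounds:
- Compound 1, `Cc1cc2c(cc1C(=O)c1ccc(C(=O)OCCCCOC(=O)c3ccc(C(=O)Nc4ccc5c(c4)C(C)(C)CCC5(C)C)cc3)cc1)C(C)(C)CCC2(C)C`: 24700 nM
- Compound 2, `C=C(c1ccc(C(=O)NCCCCCCNC(=O)c2ccc(C(=O)Nc3ccc4c(c3)C(C)(C)CCC4(C)C)cc2)cc1)c1cc2c(cc1C)C(C)(C)CCC2(C)C`: 70700 nM
- Compound 3, `CCCC(=O)OCCCCOC(=O)c1ccc(C(=O)Nc2ccc3c(c2)C(C)(C)CCC3(C)C)cc1`: 7320 nM

All three were tested in a functional assay on HL-60 cells (Homo sapiens) for inhibition, read by MTT assay, with a stated time of 48 h; on this read-out higher numbers stand for weaker inhibition and lower numbers for stronger inhibition. Compound 3 gives 7320 nM, the lowest of the three numbers, and so the strongest inhibition seen here. Compound 1 gives 24700 nM, a gap beyond the scatter. Compound 2 gives 70700 nM, the widest gap from compound 3. Compounds 1 and 2 each carry a second copy of the shared core joined through a long linker, while compound 3 carries a short ester tail instead.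

Compound 4, `CCCC(CCC)C(=O)OCCCCOC(=O)c1ccc(C(=O)Nc2ccc3c(c2)C(C)(C)CCC3(C)C)cc1`, has not been measured. It differs from compound 3 only in the ester tail: 1-propylbutyl in place of propyl on a carbonyl carbon. Among the measured compounds shown here, no step between two measured compounds isolates this kind of change, so the expected size rests on judgement alone. The step is expected to be small, a 1.1-fold lower number from compound 3 to compound 4 (0.05 log units; within the scatter), within or close to the scatter, with no clear direction. Compound 4 is therefore expected to give about 6500 nM, within a range from 2200 nM to 19000 nM.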

Compound 4, half-maximal inhibitory concentration: 914000 nM
Compound 4: the middle estimate sits 140-fold (2.15 log units) below what was measured, and the stated range ends below it.
By their numbers in this assay, from the lowest: compound 3; then compound 1; then compound 2; then compound 4.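

In this assay, the ester tail proves to be a sensitive position: putting 1-propylbutyl in place of propyl on the carbonyl carbon gives a 120-fold higher number from compound 3 to compound 4 (2.10 log units; beyond the scatter) and so a large loss of inhibition. Among the compounds shown here, this change adds only carbon atoms, with no ring, hydrogen-bond donor, hydrogen-bond acceptor or net charge, and the earlier compounds could not show its effect, as no two of them differed in one place. Nothing available here explains why the step is so large.

The compounds shown leave open whether the loss follows from the branching or from the added carbons, a question that an unbranched heptyl chain on the same carbonyl carbon would help to separate. They also leave open how a tail ending in an amine or a carboxylic acid would behave.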